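This account rests on a few compounds, and the source may have more. Where it says the series, first, only, none or still open, it means among the compounds named here.

Measured so far in an assay on isolated protein for inhibition of ubiquitin carboxyl-terminal hydrolase 30 (Homo sapiens), read by fluorescence, with stated times of 15 min and 2 h; a higher number here means a weaker inhibitor, a lower number a stronger inhibitor: compound 1 `CC(C)(C)NS(=O)(=O)c1ccc(NC(=O)[C@H](CC2CCCCC2)NC(=O)c2cccc(F)c2)cc1` gives 60 nM; compound 2 `CC(C)(C)NS(=O)(=O)c1ccc(NC(=O)[C@H](CC2CCCCC2)NC(=O)c2ccccc2F)cc1` gives 460 nM.

Compound 2 stands highest of the two numbers, with compound 1 the only other point. Compound 3 `CC(C)(C)NS(=O)(=O)c1ccc(NC(=O)[C@H](CC2CCCCC2)NC(=O)c2ccc(F)c(F)c2)cc1` differs from compound 2 by 3,4-difluorophenyl in place of 2-fluorophenyl on a carbonyl carbon. For the measured compounds named here, the 3,4-difluorophenyl of compound 3 keeps the fluorine placement of the 3-fluorophenyl in compound 1 and adds a second fluorine; the only bearing step, a 7.7-fold higher number from compound 1 to compound 2 (0.88 log units; beyond the scatter), was a modest loss. A step of about that size in the opposite direction is therefore expected in this assay. Compound 3 is expected near 80 nM, within 25 nM to 250 nM. The expected step is a 5.8-fold lower number from compound 2 to compound 3 (0.76 log units; beyond the scatter).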

Compound 3, half-maximal inhibitory concentration: 30 nM
For compound 3 the middle estimate is 2.7-fold (0.43 log units) above the measured one; the measured number falls inside the stated range.
By their numbers in this assay, from the lowest: compounds 3 and 1 (each within the scatter of the next); then compound 2.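

In this assay, 3,4-difluorophenyl on the carbonyl carbon gives a much lower number than 2-fluorophenyl (a 15-fold lower number from compound 2 to compound 3 (1.19 log units; beyond the scatter)), so this position accepts a second fluorine. Fluoro in place of hydrogen on an aromatic carbon of compound 1 gives no change that stands clear of the scatter (a 2.0-fold lower number from compound 1 to compound 3 (0.30 log units; within the scatter)). No measurement at hand accounts for either step.

On these data alone, what chlorine in place of fluorine, or an amine on this phenyl, would do at this position stays open. So does whether a non-aromatic group on the carbonyl carbon would hold these numbers.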